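From Compound 1 to Compound 3: Adding Cyclopropyloxy

The source may hold more compounds than are shown below. What is called first, only, known or untested is meant among the compounds shown, and "the series" means these compounds.

Two compounds have so far been measured in a functional assay on cells for positive allosteric modulation of G-protein coupled receptor 68 (Homo sapiens), read by a luciferase reporter and cAMP accumulation, with a stated time of 30 min, at pH 6.8 and pH 8.3, in the presence of a further agent that is not named here; on this read-out lower numbers stand for lower potency and higher numbers for higher potency (the scale is a negative logarithm):

Compound 1, `Nc1nc(NCc2ccccc2)nc(-c2ccccc2CO)n1`, gives 4.35.
Compound 2, `Nc1nc(NCc2cccc(C(F)(F)F)c2)nc(-c2ccccc2CO)n1`, gives 5.11.

Compound 1 stands lowest of the two values; its nearest neighbour is compound 2, and the step of a number 0.76 log units higher from compound 1 to compound 2 (beyond the scatter) is beyond the scatter. Compound 3, `Nc1nc(NCc2ccc(OC3CC3)cc2)nc(-c2ccccc2CO)n1`, has not yet been measured in this assay. It differs from compound 1 in one place: cyclopropyloxy in place of hydrogen on an aromatic carbon. For the measured compounds named here, the only measured step, a number 0.76 log units higher from compound 1 to compound 2 (beyond the scatter), concerns a different group at a different place on the same ring, so it bears on the present change only loosely, showing that adding a group to that ring raised the number once. Going by the values given here, no measured compound puts cyclopropyloxy in place of hydrogen, and none carries any group para to the large group, so the guidance is thin. The step in this assay is therefore expected to be small and upward, with wide uncertainty: a number 0.45 log units higher from compound 1 to compound 3 (beyond the scatter). Compound 3 is estimated to give 4.8, within a range from 4.2 to 5.5.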

Compound 3, negative logarithm of the antagonist equilibrium constant: 5.07
Estimate against measurement, compound 3: 0.27 log units below, and the stated range covers the measured number.
By their numbers in this assay, from the lowest: compound 1; then compounds 3 and 2 (each within the scatter of the next).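

In this assay, cyclopropyloxy in place of hydrogen on an aromatic carbon, para to a large group, gives a step of a number 0.72 log units higher from compound 1 to compound 3 (beyond the scatter). This shows that this place on the ring can carry a group with a three-membered ring of carbon and an oxygen, and that the number then rises rather than falls. Trifluoromethyl had already given a step of a number 0.76 log units higher from compound 1 to compound 2 (beyond the scatter), so two quite different groups on this ring now each give a higher number than hydrogen, with no compound shown going against that, and nothing shown explains why the number rises.

The compounds shown leave open which part of cyclopropyloxy goes with the rise, the oxygen or the three-membered ring, and a methoxy group or a cyclopropyl group joined directly to the ring at this place would separate the two. As far as these compounds go, it also remains open whether the rise holds for a very different group here, such as an amine or a carboxylic acid, and whether trifluoromethyl would give a similar step at this place.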